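A few compounds are considered here, and "the series" means these few. Any claim that something is new, unique, unknown or untested is made for them only; others in the source may bear on it.

Four compounds share a sugar attached to a fused two-ring core, and they differ in the group on one aromatic carbon of that core and in the core itself. Compound 1 `Cc1nc(N)c2c(-c3ccccc3)cn([C@@H]3O[C@H](CO)[C@@H](O)[C@H]3O)c2n1` carries a phenyl on that carbon, while compound 2 `Cc1nc(N)c2c(I)cn([C@@H]3O[C@H](CO)[C@@H](O)[C@H]3O)c2n1` carries an iodo in the same place. In a functional assay on K562 cells (Homo sapiens), read by MTT assay, with a stated time of 72 h (on this read-out lower numbers stand for stronger inhibition and higher numbers for weaker inhibition), compound 2 gives 5120 nM. Compound 1 reaches only a limit of the measurement in this assay, namely > 20000 nM, and so stands at the limit of > 20000 nM in this assay, at which 1 of the 3 values shown sits. The change between these two is phenyl in place of iodo on an aromatic carbon, and it produced an at least 3.9-fold higher number from compound 2 to compound 1 (0.59 log units; beyond the scatter).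

Compound 3 `CNc1ncnc2c1c(I)cn2[C@@H]1O[C@H](CO)[C@@H](O)[C@H]1O` keeps the iodo but has a different core from compound 2; the difference between the two cores is not broken down here. In this assay compound 3 also gives only a limit, > 100000 nM, and so stands at the limit of > 100000 nM in this assay, at which 1 of the 3 values shown sits.

Compound 4 `CNc1ncnc2c1c(-c1ccccc1)cn2[C@@H]1O[C@H](CO)[C@@H](O)[C@H]1O` is compound 3 with the same change that turned compound 2 into compound 1: phenyl in place of iodo on an aromatic carbon. The surroundings of the change are described in the same words for both pairs, so this is the same change rather than merely the same kind. Going by the values given here, because compound 3 already shows the limit > 100000 nM, and because the one measured example of this change weakened inhibition by an at least 3.9-fold higher number from compound 2 to compound 1 (0.59 log units; beyond the scatter), compound 4 is expected to be no stronger than compound 3, with an estimated step that the limit leaves unreadable from compound 3 to compound 4. In this assay compound 4 is therefore estimated at 300000 nM, most likely reported again only as a limit rather than a number.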

Compound 4, half-maximal inhibitory concentration: > 20000 nM
Compound 4 ended at the assay's limit (the forecaster's own chance of this, stated with the estimate: 90%); the middle value does not contradict the limit.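

Compound 3 and compound 4 both appear only as limits in this assay, not as numbers, so the step between them, phenyl in place of iodo on an aromatic carbon, cannot be read. The compounds shown leave open how strongly compound 3 and compound 4 actually inhibit, and whether this change has the same effect on the core of compound 3 as on the core of compound 2.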